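From dimethoxyphenyl to chlorophenyl on the shared core

This account rests on a few compounds, and the source may have more. Where it says the series, first, only, none or still open, it means among the compounds named here.

In a functional assay on U-87MG ATCC cells for antiproliferative activity against U-87 MG (Homo sapiens), read by MTT assay, with a stated time of 48 h (on this read-out higher numbers stand for weaker inhibition and lower numbers for stronger inhibition), compound 1 `Cc1nc(-c2ccccc2)sc1C(=O)CSc1nc(-c2ccc(Cl)c(Cl)c2)c(C#N)c(=O)[nH]1` gives 65000 nM, compound 2 `Cc1nc(-c2ccccc2)sc1C(=O)CSc1nc(-c2cccc(Cl)c2)c(C#N)c(=O)[nH]1` gives 28200 nM and compound 3 `COc1ccc(-c2nc(SCC(=O)c3sc(-c4ccccc4)nc3C)[nH]c(=O)c2C#N)cc1OC` gives 15300 nM. The widest gap among these is a 4.2-fold lower number from compound 1 to compound 3 (0.63 log units; beyond the scatter), while the closest pair shows a 1.8-fold lower number from compound 2 to compound 3 (0.27 log units; within the scatter). Compound 4 `Cc1nc(-c2ccccc2)sc1C(=O)CSc1nc(-c2ccc(Cl)cc2)c(C#N)c(=O)[nH]1` carries 4-chlorophenyl in place of 3,4-dimethoxyphenyl on an aromatic carbon. For the measured compounds named here, two measured steps bear on this change. Swapping 3,4-dichlorophenyl for the same 3,4-dimethoxyphenyl gave a 4.2-fold lower number from compound 1 to compound 3 (0.63 log units; beyond the scatter), and removing one chloro gave a 2.3-fold lower number from compound 1 to compound 2 (0.36 log units; beyond the scatter). Both steps are modest, so a modest move to a higher number is expected, namely a 2.3-fold higher number from compound 3 to compound 4 (0.36 log units; beyond the scatter). Compound 4 is estimated at 35000 nM, with an expected range from 15000 nM to 75000 nM.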

Compound 4, half-maximal inhibitory concentration: 43400 nM
The estimate for compound 4 lay 1.2-fold (0.09 log units) below the measured number, and the stated range covers the measured number.
By their numbers in this assay, from the lowest: compounds 3, 2, 4 and 1 (each within the scatter of the next, the first and the last beyond it).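

In this assay, 4-chlorophenyl in place of 3,4-dimethoxyphenyl on this carbon, which sits ortho to the cyano group, gave a step beyond the scatter (a 2.8-fold higher number from compound 3 to compound 4 (0.45 log units; beyond the scatter)). The new compound adds a third chlorophenyl group, yet it cannot be told apart from 3-chlorophenyl (a 1.5-fold higher number from compound 2 to compound 4 (0.19 log units; within the scatter)) or from 3,4-dichlorophenyl (a 1.5-fold lower number from compound 1 to compound 4 (0.18 log units; within the scatter)), so where the chloro sits on this ring shows no clear effect in this pair. Nothing measured here explains these steps. The compounds shown leave open whether a single methoxy group would behave like the pair, and how an amine or a carboxylic acid on this phenyl ring would read.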